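A few compounds are considered here, and "the series" means these few. Any claim that something is new, unique, unknown or untested is made for them only; others in the source may bear on it.

Compound 1 `Cn1c(-c2cccc(Cl)c2)nc2c(NC3CCCC3)ncnc21` is the reference point here: in an assay on CHO cells for displacement of a labelled ligand from adenosine receptor A1 (Homo sapiens), read by scintillation counting, with a stated time of 3 h (on this read-out lower numbers stand for stronger inhibition and higher numbers for weaker inhibition), compound 1 gives 6.5 nM. Compound 2 `COc1ccc(-c2nc3c(NC4CCCC4)ncnc3n2C)cc1` differs from it only in the aryl group, and in this assay compound 2 gives 75 nM, which is a 12-fold higher number from compound 1 to compound 2 (1.06 log units; beyond the scatter). For the measured compounds named here, compound 2 therefore carries the higher of the two numbers measured so far, with compound 1 as its only neighbour.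

Compound 3 `Cn1c(-c2ccc(O)cc2)nc2c(NC3CCCC3)ncnc21` is made from compound 2 by one change: hydrogen in place of methyl on an oxygen on an aromatic ring. Going by the values given here, no measured step touches this oxygen; the single step known, from compound 1 to compound 2, concerns a different part of the aryl group and gives no guide to the size or direction of the present change. The step is therefore expected to be a 1.1-fold lower number from compound 2 to compound 3 (0.03 log units; within the scatter), no more than the scatter would allow. Compound 3 is estimated at 70 nM, within 20 nM to 250 nM.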

Compound 3, inhibition constant: 17 nM
For compound 3 the middle estimate is 4.1-fold (0.61 log units) above the measured one, outside the stated range (below it).
By their numbers in this assay, from the lowest: compound 1; then compound 3; then compound 2.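

In this assay, the group on the oxygen on the aromatic ring proves to matter: hydrogen in place of methyl, methoxy to hydroxy, gives a 4.4-fold lower number from compound 2 to compound 3 (0.64 log units; beyond the scatter). The 4-hydroxyphenyl group thus recovers part of the ground lost by the 4-methoxyphenyl group against the 3-chlorophenyl group. It does not close the gap, however, as the comparison with the chlorinated compound gives a 2.6-fold higher number from compound 1 to compound 3 (0.42 log units; beyond the scatter).

Nothing available explains why hydroxy gives the lower number here. The compounds shown leave open how much of the remaining gap belongs to the group itself and how much to where it sits on the aryl ring, and whether an amine or an ethoxy group in place of hydroxy would fall nearer to compound 3 or to compound 2.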